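This account rests on a few compounds, and the source may have more. Where it says the series, first, only, none or still open, it means among the compounds named here.

Two compounds have been measured in an ADME assay on microsomes from liver (Homo sapiens) for pharmacokinetics, read by LC-MS, with a stated time of 60 min, tested at 1 uM (a higher number here means faster removal of the compound, a lower number slower removal), so far, with these values:

- compound 1 `O=C(NCc1cnccn1)Nc1ccc(S(=O)(=O)c2ccccc2)cc1` at 5 mL/min/kg
- compound 2 `C[C@@H]1COC[C@@H](C)N1S(=O)(=O)c1ccc(NC(=O)NCc2cccnc2)cc1` at 17 mL/min/kg

Compound 2 holds the higher of the two numbers, and its gap to compound 1 lies beyond the scatter. Compound 3 `O=C(NCc1cccnc1)Nc1ccc(S(=O)(=O)N2CC3(COC3)C2)cc1` has not yet been measured. It departs from compound 2 on a sulfonyl sulfur (a group of 7 heavy atoms (5 carbon, 1 nitrogen, 1 oxygen; 2 four-membered non-aromatic rings with 1 hetero atom each) in place of a group of 8 heavy atoms (6 carbon, 1 nitrogen, 1 oxygen; one six-membered non-aromatic ring with 2 hetero atoms), on a sulfonyl sulfur), where the 3,5-dimethylmorpholin-4-yl group leaves. Within the data shown here, no measured step covers this change, so the data offer no direct guide to its size. Among the measured compounds shown here, a modest fall in this assay is nevertheless expected, and compound 1 at 5 mL/min/kg shows only that lower numbers occur in this small set. An expected 2.1-fold lower number from compound 2 to compound 3 (0.33 log units; beyond the scatter) would sit near the edge of the scatter. Compound 3 is estimated at 8 mL/min/kg (range 4 mL/min/kg to 16 mL/min/kg).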

Compound 3, clearance: 7 mL/min/kg
Compound 3: the middle estimate sits 1.1-fold (0.06 log units) above what was measured, and the stated range covers the measured number.
By their numbers in this assay, from the lowest: compounds 1 and 3 (each within the scatter of the next); then compound 2.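

In this assay, among these compounds, this gives the first readable change on the sulfonyl sulfur: exchanging the 3,5-dimethylmorpholin-4-yl group for the group with 2 four-membered non-aromatic rings gives a 2.4-fold lower number from compound 2 to compound 3 (0.39 log units; beyond the scatter). The step shows that the group held on this sulfur, whose other neighbour is an aromatic carbon, can alter the clearance of this series by a modest amount, here with a group that has no defined stereocentres replacing one that has 2. No available evidence bears on the reason for this step.

The compounds shown leave open how a plain morpholin-4-yl group or a dimethylamino group on the sulfonyl sulfur would compare with the groups in compound 2 and compound 3. They also leave open whether this exchange would give a step of similar size if another part of compound 2 were different.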